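Chloro in place of methoxy: expecting little movement

This account rests on a few compounds, and the source may have more. Where it says the series, first, only, none or still open, it means among the compounds named here.

Measured compounds:
compound 1 `COc1ccc(-c2nc(SCC(=O)c3sc(-c4ccccc4)nc3C)[nH]c(=O)c2C#N)cc1`: 90.4%
compound 2 `Cc1nc(-c2ccc(Cl)cc2)sc1C(=O)CSc1nc(-c2cccc(Cl)c2)c(C#N)c(=O)[nH]1`: 95.2%
compound 3 `COc1ccc(-c2nc(SCC(=O)c3sc(-c4ccc(Cl)cc4)nc3C)[nH]c(=O)c2C#N)cc1`: 88.3%

All three values come from a functional assay on U-87MG ATCC cells for antiproliferative activity against U-87 MG (Homo sapiens), read by MTT assay, with a stated time of 48 h, tested at 10 uM; on this read-out higher numbers stand for a weaker effect at the one concentration tested and lower numbers for a stronger effect. Compound 1 stands second highest of the three numbers. Its nearest neighbour is compound 3, reached by a number 2.1 percentage points lower from compound 1 to compound 3 (within the scatter), a step described as chloro in place of hydrogen on an aromatic carbon. For the measured compounds named here, compound 2 sits a little higher than compound 1, and the two values lie within the usual scatter of each other; no single-point step between compounds 1 and 2 is given.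

The compound now in question is compound 4 `Cc1nc(-c2ccccc2)sc1C(=O)CSc1nc(-c2ccc(Cl)cc2)c(C#N)c(=O)[nH]1`. It differs from compound 1 by chloro in place of methoxy on an aromatic carbon. Going by the values given here, two measured steps bear on this. The first, a number 2.1 percentage points lower from compound 1 to compound 3 (within the scatter), adds a chloro on the same kind of aromatic carbon and stays within the scatter. The second, a number 6.9 percentage points lower from compound 2 to compound 3 (within the scatter), exchanges 4-methoxyphenyl for 3-chlorophenyl and also stays within the scatter. Neither step moved this assay by more than the noise, so no step beyond the scatter is expected from compound 1 to compound 4.

Compound 4 is therefore expected to give 91%, with a range from 82% to 99%. The expected step of a number 0.6 percentage points higher from compound 1 to compound 4 (within the scatter) is estimated to be small and of no settled direction.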

Compound 4, a percentage reported as activity, at one concentration (the size of the read-out at that concentration, not a potency): 85.2%
Compound 4: middle estimate off by 5.8 percentage points, on the high side, within the range that was stated.
By their numbers in this assay, from the lowest: compounds 4, 3, 1 and 2 (each within the scatter of the next).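

In this assay, the exchange of 4-methoxyphenyl for 4-chlorophenyl gives a number 5.2 percentage points lower from compound 1 to compound 4 (within the scatter), with the rest of the molecule unchanged. For the compounds shown here, this is the first direct comparison of methoxy and chloro at one and the same place, on an aromatic carbon of a six-membered aromatic ring of carbon only, para to a large group; the earlier step between compound 2 and compound 3 changed the substituted phenyl from 3-chlorophenyl to 4-methoxyphenyl, so the group and its place on the ring changed together. At this place, and with this partner on the rest of the core, the read-out does not separate the two groups, and nothing shown offers an explanation for the size of the step.

From the compounds shown here alone, whether any group at this place can move the read-out beyond the scatter stays open, for instance an amine, a carboxylic acid or a longer chain such as butoxy. A reading at one concentration also leaves open whether compound 1 and compound 4 would differ in potency.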